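Cyclobutyl for oxan-4-yl on the amide nitrogen

The compounds below may be only part of what the source reports. "The series", "measured", "known", "first", "only" and "open" are said of these compounds alone.

Measured so far:
compound 1 `CNC(=O)c1ccc(=O)n(Cc2cc(Br)ccc2F)c1` — 2.6
compound 2 `CNC(=O)c1cc(C(=O)NC2CCOCC2)cn(Cc2ccccc2)c1=O` — 2.8
compound 3 `CNC(=O)c1cc(C(=O)NC2CC2)c(C)n(Cc2ccccc2)c1=O` — 2.9

Three compounds of the series have been run in a physicochemical assay for lipophilicity, at pH 7.4; a higher number here means a more lipophilic compound, a lower number a more polar compound. Compound 1 `CNC(=O)c1ccc(=O)n(Cc2cc(Br)ccc2F)c1` gives 2.6, compound 2 `CNC(=O)c1cc(C(=O)NC2CCOCC2)cn(Cc2ccccc2)c1=O` gives 2.8, and compound 3 `CNC(=O)c1cc(C(=O)NC2CC2)c(C)n(Cc2ccccc2)c1=O` gives 2.9. The three numbers lie within the usual scatter of one another, so none of them can be told apart from the others; compound 2 sits in the middle of the group, with compound 3 a touch higher and compound 1 a touch lower, neither gap meaning anything.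

Compound 4 `CNC(=O)c1cc(C(=O)NC2CCC2)cn(Cc2ccccc2)c1=O` is the next to be measured in this assay. It differs from compound 2 in one place: cyclobutyl in place of oxan-4-yl on an amide-type nitrogen. The ring that leaves carries a hetero atom and a hydrogen-bond acceptor; the ring that enters has neither and two heavy atoms fewer. Among the compounds with values here, no step between two measured compounds of this kind is available to calibrate against, so the expectation rests on the change alone. The step from compound 2 to compound 4 is expected to be a number 0.50 log units higher from compound 2 to compound 4 (beyond the scatter), upward and beyond the scatter. Compound 4 is estimated at 3.3, in the range 2.9 to 3.8.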

Compound 4, distribution coefficient: 3.8
For compound 4 the middle estimate is 0.50 log units below the measured one; the measured number falls inside the stated range.
By their numbers in this assay, from the lowest: compounds 1, 2 and 3 (each within the scatter of the next); then compound 4.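

In this assay, cyclobutyl in place of oxan-4-yl on the amide-type nitrogen gives a number 1.00 log units higher from compound 2 to compound 4 (beyond the scatter). Within the data shown here, this is the first step between two compounds that differ in one place, and it shows that the number responds to the ring on this nitrogen, which the three earlier values, all within the scatter of one another, could not show. No measurement at hand bears on the cause of this step.

The ring that enters differs from the ring that leaves in size, oxygen and acceptor all at once, and this single pair cannot separate them. Cyclohexyl on the same nitrogen would set ring size apart from the oxygen, while piperidin-4-yl, a ring holding an amine, and the core of compound 3 remain open questions for this change.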